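From a Single Enantiomer to Its Unresolved Form

A few compounds are considered here, and "the series" means these few. Any claim that something is new, unique, unknown or untested is made for them only; others in the source may bear on it.

Compound 2 `C[C@@H](C(=O)N1CCC(F)(F)CC1)N1CCN(S(=O)(=O)c2ccc(C(C)(C)C)cc2)CC1` carries one stereocentre drawn in a set configuration on its saturated chain carbon. In an ADME assay on HepG2 cells (Homo sapiens) for inhibition, with a stated time of 48 h (a lower number here means that less compound is needed, a higher number that more compound is needed for the effect), compound 2 reaches only the limit of the assay, > 40000 nM, and no number. Compound 1 `CC(C(=O)N1CCCCCC1)N1CCN(S(=O)(=O)c2ccc(C(C)(C)C)cc2)CC1`, the analogue with a seven-membered amide ring and no drawn configuration, also stops at the limit in this assay, giving > 40000 nM. Every value shown therefore rests at one place: the limit of > 40000 nM in this assay, at which 2 of the 2 values shown sit. Among the compounds with values here, compound 2 thus stands at the edge of what this assay can report, with no measured compound anywhere else on the scale to compare it against.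

Compound 3 `CC(C(=O)N1CCC(F)(F)CC1)N1CCN(S(=O)(=O)c2ccc(C(C)(C)C)cc2)CC1` keeps every atom and bond of compound 2 and differs only in how the stereocentre is drawn: the two compounds have the same atoms and bonds; at least one stereo element is drawn with a configuration in one of them and without one in the other: 1 of 1 stereo elements differ; a stereocentre at a saturated chain carbon is drawn S in compound 2 and without a configuration in compound 3. Within the data shown here, no step between measured compounds is available here, so no measured size of change can be cited. The step from compound 2 to compound 3 is expected to be none beyond the scatter, a step that the limit leaves unreadable from compound 2 to compound 3. Compound 3 is accordingly estimated at 60000 nM, within 30000 nM to 200000 nM, and is most likely to come back as a limit rather than a number.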

Compound 3, half-maximal effective concentration: > 40000 nM
Compound 3 ended at the assay's limit (the forecaster's own chance of this, stated with the estimate: 85%); the middle value lies beyond the limit too.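

In this assay compound 3 gives > 40000 nM, which is a limit and not a number. Within the data shown here, no step from compound 2 or compound 1 to compound 3 can be read, because every value rests at one place: the limit of > 40000 nM in this assay, at which 3 of the 3 values shown sit. The compounds shown leave open whether the drawn configuration or the amide ring changes the effect at all.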